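Methylsulfanyl in place of methylsulfonyl: expected outcome

The compounds below may be only part of what the source reports. "The series", "measured", "known", "first", "only" and "open" are said of these compounds alone.

Compound 1 `NC(=O)c1ccc2c(c1)nc(Nc1ccc(S(N)(=O)=O)cc1)n2Cc1ccccn1`: > 50000 nM
Compound 2 `COc1ccc(Nc2nc3cc(C(N)=O)ccc3n2Cc2ccccc2C(F)(F)F)cc1F`: > 50000 nM
Compound 3 `CS(=O)(=O)c1ccc(Nc2nc3cc(C(=O)O)ccc3n2Cc2ccccc2C(F)(F)F)cc1`: > 50000 nM

In an assay on isolated protein for inhibition of kinesin heavy chain isoform 5A (Homo sapiens) (on this read-out higher numbers stand for weaker inhibition and lower numbers for stronger inhibition), compound 3 gives > 50000 nM, which is a limit of the assay and not a number. Compound 1 also sits at a limit, > 50000 nM. Compound 2 likewise sits at a limit, > 50000 nM. All three shown values therefore share (the limit of > 50000 nM in this assay, at which 3 of the 3 values shown sit), so compound 3 stands nowhere distinguishable among them. Compound 4 `CSc1ccc(Nc2nc3cc(C(=O)O)ccc3n2Cc2ccccc2C(F)(F)F)cc1` differs from compound 3 in one place: methylsulfanyl in place of methylsulfonyl on an aromatic carbon. For the measured compounds named here, no step between measured compounds is available, so no direction beyond the scatter is predicted for this assay; the expectation is that compound 4 stays near the limit. The step from compound 3 to compound 4 is estimated as a step that the limit leaves unreadable from compound 3 to compound 4. Compound 4 is expected to give 60000 nM, within 15000 nM to 250000 nM.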

Compound 4, half-maximal inhibitory concentration: > 50000 nM
Compound 4: a limit, no number (the forecaster's own chance of this, stated with the estimate: 80%); the middle value does not contradict the limit.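

No step can be read from compound 3 to compound 4 in this assay, since both values are limits of the assay and not numbers: the limit of > 50000 nM in this assay, at which 4 of the 4 values shown sit.

The compounds shown leave open whether this assay gives a measurable value for anything in this series.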